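This account rests on a few compounds, and the source may have more. Where it says the series, first, only, none or still open, it means among the compounds named here.

Measured so far:
compound 1 `O=C(CN1CCN(c2cccc(C(F)(F)F)c2)CC1)N(c1ccccc1)c1ccccc1`: 48 mg/kg
compound 2 `O=C(CN1CCN(c2ccc(Cl)c(Cl)c2)CC1)N(c1ccccc1)c1ccccc1`: 45 mg/kg

In a toxicity assay on the whole organism (strain albino) for activation, with Mus musculus as the target, with stated times of 30 min and 240 min (a lower number here means that less compound is needed, a higher number that more compound is needed for the effect), compound 1 gives 48 mg/kg, and in this assay compound 2 gives 45 mg/kg. These two numbers lie within the scatter of each other: the step of a 1.1-fold lower number from compound 1 to compound 2 (0.03 log units; within the scatter) is too small to count as a real difference, so compound 2 cannot be set apart from compound 1 on these data.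

Compound 3 `O=C(CN1CCN(c2ccc([N+](=O)[O-])cc2)CC1)N(c1ccccc1)c1ccccc1` has not yet been measured. It differs from compound 2 in one place: 4-nitrophenyl in place of 3,4-dichlorophenyl on an amine nitrogen in a ring. Among the measured compounds shown here, the only measured step that bears on this change is the one from compound 1 to compound 2, which also swapped the group on the same ring nitrogen and gave a 1.1-fold lower number from compound 1 to compound 2 (0.03 log units; within the scatter). For the measured compounds named here, no measured step brings in a nitrophenyl group, so there is nothing to show that this new group would behave differently from the two already seen. On that basis the expected step of no change at the digits printed from compound 2 to compound 3 (within the scatter) is none beyond the scatter. Compound 3 is therefore estimated at 45 mg/kg in this assay, with a range from 20 mg/kg to 100 mg/kg.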

Compound 3, dose for half-maximal effect: > 40 mg/kg
Compound 3: no number, only a limit (the forecaster's own chance of this, stated with the estimate: 5%); the middle value is on the limit's open side.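

In this assay compound 3 gives > 40 mg/kg, which is a limit and not a number. Among the compounds shown here, no step from compound 1 or compound 2 to compound 3 can be read from it. The compounds shown leave open whether 4-nitrophenyl on the ring nitrogen sets compound 3 apart from compound 1 and compound 2.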